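The source may report more compounds than this note shows. Statements on the series, on what has been measured and on what is new or still open speak of the compounds shown alone.

Compound 1 `CCCCCCCCCCCC[C@@H](O)[C@H]1CC[C@H]([C@H](O)CCCCCCCCCCNC(=O)c2ccnn2C)O1` stands highest of the three numbers in a functional assay (RXF 631 cells, Homo sapiens) for inhibition, read by sulforhodamine B assay, with a stated time of 48 h (a lower number here means a stronger inhibitor of growth, a higher number a weaker inhibitor of growth), at 100000 nM; compound 2 `CCCCCCCCCCCC[C@@H](O)[C@H]1CC[C@H]([C@H](O)CCCCCCCCCCN(C)C(=O)c2ccnn2C)O1` reads 11000 nM and compound 3 `CCCCCCCCCCCC[C@@H](O)[C@H]1CC[C@H]([C@H](O)CCCCCCCCCCNCc2ccnn2C)O1` reads 2400 nM. Compound 4 `CCCCCCCCCCCC[C@@H](O)[C@H]1CC[C@H]([C@H](O)CCCCCCCCCCOC(=O)c2ccnn2C)O1` alters only the group on the saturated chain carbon: ((1-methyl-1H-pyrazol-5-yl)carbonyl)oxy in place of ((1-methyl-1H-pyrazol-5-yl)carbonyl)amino on a saturated chain carbon, ten or more bonds along the chain from an oxygen on a saturated carbon and a saturated ring carbon. The carbonyl stays and the amide hydrogen goes. Within the data shown here, the closest precedent is the modest 9.1-fold lower number from compound 1 to compound 2 (0.96 log units; beyond the scatter), which also removes that hydrogen and keeps the carbonyl. The large 42-fold lower number from compound 1 to compound 3 (1.62 log units; beyond the scatter) removes the carbonyl instead and bears less directly. Among the measured compounds shown here, no measured compound carries the oxy link, so a modest move to a lower number is expected, with wide uncertainty. The expected step is a 10-fold lower number from compound 1 to compound 4 (1.00 log units; beyond the scatter). Compound 4 is estimated at 10000 nM, with an expected range of 2500 nM to 50000 nM.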

Compound 4, concentration for 50% growth inhibition: 100000 nM
Compound 4: middle estimate off by 10-fold (1.00 log units), on the low side; measured number above the stated range.
By their numbers in this assay, from the lowest: compound 3; then compound 2; then compounds 1 and 4 (each within the scatter of the next).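

In this assay the oxy link in place of the amide nitrogen gives no change at the digits printed from compound 1 to compound 4 (within the scatter), so losing the amide hydrogen alone does not reproduce the step seen with methyl on that nitrogen. The steps of a 9.1-fold higher number from compound 2 to compound 4 (0.96 log units; beyond the scatter) and a 42-fold higher number from compound 3 to compound 4 (1.62 log units; beyond the scatter) leave the oxy link on the higher number, yet compound 1 keeps its nitrogen and prints the same value, so nitrogen alone does not bring the lower numbers. No evidence on hand explains this result. Left open is whether ethyl on the amide nitrogen follows methyl, and whether a sulfonamide link reads nearer compound 3 or compound 4.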